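Swapping the furan arm for a hydroxyphenyl arm

A few compounds are considered here, and "the series" means these few. Any claim that something is new, unique, unknown or untested is made for them only; others in the source may bear on it.

Of the compounds shown here, three sharing one core have been tested in a functional assay on HGC-27 cells (Homo sapiens) for antiproliferative activity, read by MTT assay, with a stated time of 72 h; on this read-out lower numbers stand for stronger inhibition and higher numbers for weaker inhibition. Compound 1 `CCCSc1nc(Nc2ccccc2)c2nc(Nc3ccccc3)sc2n1` gives 35300 nM, compound 2 `CCCSc1nc(NCc2ccco2)c2nc(Nc3ccccc3)sc2n1` gives 28000 nM, and compound 3 `CCCSc1nc(Nc2ccc(Cl)cc2)c2nc(Nc3ccccc3)sc2n1` gives 20300 nM. The number for compound 2 is the second highest of the three, though all three lie within the scatter of one another: a 1.3-fold lower number from compound 1 to compound 2 (0.10 log units; within the scatter), a 1.4-fold lower number from compound 2 to compound 3 (0.14 log units; within the scatter) and a 1.7-fold lower number from compound 1 to compound 3 (0.24 log units; within the scatter). Compound 4 `CCCSc1nc(NCc2ccc(O)cc2)c2nc(Nc3ccccc3)sc2n1` differs from compound 2 by 4-hydroxyphenyl in place of furan-2-yl on a saturated chain carbon bound to a nitrogen on an aromatic ring. The two earlier changes at this same position, a 1.3-fold lower number from compound 1 to compound 2 (0.10 log units; within the scatter) and a 1.4-fold lower number from compound 2 to compound 3 (0.14 log units; within the scatter), both stayed within the scatter. No step beyond the scatter is therefore expected for compound 4, a 1.1-fold lower number from compound 2 to compound 4 (0.05 log units; within the scatter). Compound 4 is estimated at 25000 nM, with a range from 10000 nM to 60000 nM.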

Compound 4, half-maximal inhibitory concentration: 17300 nM
The estimate for compound 4 lay 1.4-fold (0.16 log units) above the measured number, within the range that was stated.
By their numbers in this assay, from the lowest: compounds 4, 3, 2 and 1 (each within the scatter of the next, the first and the last beyond it).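

In this assay, 4-hydroxyphenyl can take the place of furan-2-yl with no readable change, even though it brings a hydrogen-bond donor: a 1.6-fold lower number from compound 2 to compound 4 (0.21 log units; within the scatter), and likewise a 1.2-fold lower number from compound 3 to compound 4 (0.07 log units; within the scatter). Going by these compounds alone, at this position, only a 2.0-fold lower number from compound 1 to compound 4 (0.31 log units; beyond the scatter) passes the scatter, making it the first modest step here that can be told apart from noise. Nothing measured here explains that step. Still open, on these data alone, is whether the hydroxyl matters at all, since a plain benzyl, 4-methoxybenzyl or 4-aminobenzyl group could show how much the number depends on it.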